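A few compounds are considered here, and "the series" means these few. Any claim that something is new, unique, unknown or untested is made for them only; others in the source may bear on it.

Compound 1 `O=C(CCN1CCN(c2ccc(F)cc2)CC1)c1ccccc1`, compound 2 `O=C(CCN1CCN(c2ccc(C(F)(F)F)cc2)CC1)c1ccccc1` and compound 3 `O=C(CCN1CCN(c2ccc(F)cc2)CC1)c1ccc(Br)cc1` are measured; compound 4 `O=C(CCN1CCN(c2ccc(C(F)(F)F)cc2)CC1)c1ccc(Br)cc1` is not yet. In an ADME assay on Vero cells (Chlorocebus sabaeus) for cytotoxicity, read by resazurin assay, with a stated time of 72 h (a lower number here means a stronger inhibitor, a higher number a weaker inhibitor), compound 1 gives 13400 nM, compound 2 gives 15700 nM and compound 3 gives 99500 nM. The change from compound 1 to compound 2 is trifluoromethyl in place of fluoro on an aromatic carbon and it made a 1.2-fold higher number from compound 1 to compound 2 (0.07 log units; within the scatter). The two cores differ in this way: bromo in place of hydrogen on an aromatic carbon, a change that made a 7.4-fold higher number from compound 1 to compound 3 (0.87 log units; beyond the scatter). The change from compound 3 to compound 4 is trifluoromethyl in place of fluoro on an aromatic carbon, the same change at the same kind of place. Compound 4 is expected to show a 1.2-fold higher number from compound 3 to compound 4 (0.06 log units; within the scatter) because the earlier instance of this change gave a 1.2-fold higher number from compound 1 to compound 2 (0.07 log units; within the scatter). The expected value for compound 4 is 115000 nM, with a likely range from 55000 nM to 250000 nM.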

Compound 4, half-maximal inhibitory concentration: 78800 nM
Estimate against measurement, compound 4: 1.5-fold (0.16 log units) above; the measured number falls inside the stated range.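

In this assay, trifluoromethyl in place of fluoro gave a 1.3-fold lower number from compound 3 to compound 4 (0.10 log units; within the scatter) on the bromo-bearing core, a step that matches the earlier one on the core without bromo: the same change on two cores in this assay, a 1.2-fold higher number (0.07 log units; within the scatter) from compound 1 to compound 2 and a 1.3-fold lower number (0.10 log units; within the scatter) from compound 3 to compound 4, 1.5-fold (0.17 log units) apart, within the scatter of two such steps. Bromo in place of hydrogen gave a 5.0-fold higher number from compound 2 to compound 4 (0.70 log units; beyond the scatter) and so carried over from the fluoro compounds to the trifluoromethyl compounds: the same change on two cores in this assay, a 7.4-fold higher number (0.87 log units; beyond the scatter) from compound 1 to compound 3 and a 5.0-fold higher number (0.70 log units; beyond the scatter) from compound 2 to compound 4, 1.5-fold (0.17 log units) apart, within the scatter of two such steps. Across these four compounds, each change therefore gives much the same step whichever form the other group takes, but this rests on a single pair of steps per change and shows neither why the steps have these sizes nor that they would hold on other cores.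

Going by these compounds, whether chloro or an amine in place of bromo would give a step of similar size remains open. So does the effect of a longer chain leading to the carbonyl.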